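Swapping a para methoxy for chloro on a bis-benzimidazole hydrazone

This account rests on a few compounds, and the source may have more. Where it says the series, first, only, none or still open, it means among the compounds named here.

Of the compounds shown here, three sharing one core have been measured in a functional assay on CCRF-CEM cells (Homo sapiens) for cytotoxicity, read by MTT assay, with a stated time of 72 h; a higher number here means a weaker inhibitor, a lower number a stronger inhibitor. Compound 1 `c1ccc(NN=C(c2nc3ccccc3[nH]2)c2nc3ccccc3[nH]2)cc1` carries an unsubstituted phenyl ring on the hydrazone nitrogen, and in this assay compound 1 gives 27900 nM. Compound 2 `Cc1ccc(NN=C(c2nc3ccccc3[nH]2)c2nc3ccccc3[nH]2)cc1` adds a methyl to that ring, and compound 2 gives 87600 nM. Compound 3 `COc1ccc(NN=C(c2nc3ccccc3[nH]2)c2nc3ccccc3[nH]2)cc1` instead carries a methoxy, and compound 3 gives 96700 nM, the highest number of the three; its number and that of compound 2 sit within the scatter of each other, while it stands beyond the scatter from compound 1.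

Going by the values given here, two steps bear on what a para substituent does here: a 3.1-fold higher number from compound 1 to compound 2 (0.50 log units; beyond the scatter) and a 3.5-fold higher number from compound 1 to compound 3 (0.54 log units; beyond the scatter). Between the two substituents themselves, a 1.1-fold higher number from compound 2 to compound 3 (0.04 log units; within the scatter).

Compound 4 `Clc1ccc(NN=C(c2nc3ccccc3[nH]2)c2nc3ccccc3[nH]2)cc1` is the next member, differing from compound 3 in one place: chloro in place of methoxy on an aromatic carbon. Among the compounds with values here, no measured step involves chloro, so the expectation rests on the two substituted compounds behaving alike. The step from compound 3 to compound 4 is therefore expected to be small, a 1.2-fold lower number from compound 3 to compound 4 (0.08 log units; within the scatter), with either direction possible. For compound 4 the estimate in this assay is 80000 nM, within a range of 30000 nM to 200000 nM.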

Compound 4, half-maximal inhibitory concentration: 112000 nM
The estimate for compound 4 lay 1.4-fold (0.15 log units) below the measured number; the measured number falls inside the stated range.
By their numbers in this assay, from the lowest: compound 1; then compounds 2, 3 and 4 (each within the scatter of the next).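

In this assay, a step of a 1.2-fold higher number from compound 3 to compound 4 (0.06 log units; within the scatter) and one of a 1.3-fold higher number from compound 2 to compound 4 (0.11 log units; within the scatter) place chloro alongside methoxy and methyl, and these three substituents cannot be told apart at this position. Chloro also gives a step of a 4.0-fold higher number from compound 1 to compound 4 (0.60 log units; beyond the scatter) and so joins methyl and methoxy in sitting beyond the scatter from the unsubstituted ring of compound 1, which makes this a shared gap across three different substituents. No measurement shown here explains why these three compounds group together.

The compounds shown leave open whether an amine, a carboxylic acid or a longer chain at this position would also match compounds 2, 3 and 4. They also leave open whether any group on this ring can give a lower number than compound 1 does.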